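Moving the Bromine Around the Ring

A few compounds are considered here, and "the series" means these few. Any claim that something is new, unique, unknown or untested is made for them only; others in the source may bear on it.

Going by the values given here, compound 1, `O=C1Nc2ccc(Br)cc2/C1=N/NC(=S)N/N=C/c1ccc(Br)cc1`, is the only compound here that returns a number in a functional assay on HeLa cells (Homo sapiens) for inhibition, read by MTT assay; on this read-out higher numbers stand for weaker inhibition and lower numbers for stronger inhibition: compound 1 gives 4680 nM. Compound 2, `Cc1ccc2c(c1)/C(=N/NC(=S)N/N=C/c1ccc(-c3ccccc3)cc1)C(=O)N2`, returns only a limit of this assay, > 50000 nM. Compound 3, `COc1ccc(/C=N/NC(=S)N/N=C2\C(=O)Nc3ccc(C)cc32)c(OC)c1`, likewise returns only a limit of this assay, > 50000 nM. Among the compounds with values here, compound 1 therefore stands as the single measured point from which a step can be taken, and no step between two measured compounds is available to guide the size of what follows.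

Compound 4, `O=C1Nc2ccc(Br)cc2/C1=N/NC(=S)N/N=C/c1ccccc1Br`, differs from compound 1 by 2-bromophenyl in place of 4-bromophenyl on a carbon with a double bond to nitrogen. The shared core of compound 1 and compound 4, with its thiosemicarbazone linkage, is otherwise unchanged.

Within the data shown here, with no measured step to lean on, the step of a 1.4-fold higher number from compound 1 to compound 4 (0.14 log units; within the scatter) is expected to be modest, toward weaker inhibition if anything, and it may well stay within the scatter. For compound 4 the estimate in this assay is 6500 nM, with a range from 2000 nM to 25000 nM.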

Compound 4, half-maximal inhibitory concentration: > 50000 nM
Compound 4: a limit, no number; the forecaster's own chance of this, stated with the estimate: 15%; at least 7.6-fold (0.88 log units) between middle value and limit.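

In this assay, going by these compounds alone, the change from 4-bromophenyl to 2-bromophenyl on a carbon with a double bond to nitrogen gives an at least 10-fold higher number from compound 1 to compound 4 (1.02 log units; beyond the scatter) and is the first step that can be read in this set. Compound 4 gives > 50000 nM in this assay, which is a limit and not a number. Within the data shown here, with the same atoms in both compounds, the step shows that the place of the bromine alone separates the only measured compound from a limit, though the reading reaches no further than that limit: the limit of > 50000 nM in this assay, at which 3 of the 4 values shown sit.

As far as these compounds go, how far the step extends past the limit stays open. Also open, from the compounds shown here alone, is whether a group such as an amine or a carboxylic acid on the phenyl ring, in place of the bromine, would keep a measurable number in this assay.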